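The compounds below may be only part of what the source reports. "The series", "measured", "known", "first", "only" and "open" are said of these compounds alone.

In an ADME assay on HeLa cells (Homo sapiens) for cytotoxicity, read by crystal violet staining, with a stated time of 72 h (a higher number here means that more compound is tolerated, a lower number that less compound is tolerated), compound 1 (`CCOC(=O)c1cc(CCCOc2ccc(-c3noc(C(F)(F)F)n3)cc2[N+](=O)[O-])on1`) gives > 100000 nM as a limit of the assay, not a number. Among the measured compounds shown here, compound 2 (`CCOC(=O)c1cc(CCCOc2ccc(-c3noc(C(F)(F)F)n3)cc2F)on1`) gives 60200 nM as the only actual number so far. Compound 3 (`CN(C)C(=O)c1cc(CCCOc2ccc(-c3noc(C(F)(F)F)n3)cc2F)on1`) carries dimethylamino in place of ethoxy on a carbonyl carbon, counted as dimethylamino in place of ethoxy on a carbonyl carbon and also readable as ethoxycarbonyl to dimethylcarbamoyl. For the measured compounds named here, the sole measured step, an at least 1.6-fold lower number from compound 1 to compound 2 (0.22 log units; that floor lies within the scatter) for fluoro in place of nitro on an aromatic carbon, concerns a different group, and its floor lies within the scatter. Going by the values given here, no measured step touches the ethoxycarbonyl group, so no step beyond the scatter is expected in this assay in either direction. The expected change is a 1.2-fold higher number from compound 2 to compound 3 (0.07 log units; within the scatter) and no more than that. For compound 3 the estimate is 70000 nM with an expected range from 30000 nM to 100000 nM at this stage.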

Compound 3, half-maximal cytotoxic concentration: 20200 nM
Compound 3: middle estimate off by 3.5-fold (0.54 log units), on the high side, outside the stated range (below it).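

In this assay, the group on the carbonyl carbon proves able to move the number: dimethylamino in place of ethoxy gives a 3.0-fold lower number from compound 2 to compound 3 (0.47 log units; beyond the scatter), so less compound is tolerated with the dimethylcarbamoyl group than with the ethoxycarbonyl group. This is the only step shown that is beyond the scatter, and the only one with a number at both ends. The earlier step gives only a floor, as the value of compound 1 is a limit: the limit of > 100000 nM in this assay, at which 1 of the 3 values shown sits.

Still open, from the compounds shown here alone, is whether the lower number is particular to dimethylamino, or also appears with a primary amide, a carboxylic acid or a longer ester chain on the same carbonyl carbon. Also open, going by these compounds, is whether the same exchange gives a step of this size with nitro in place of fluoro on the aromatic carbon.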